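Urea aryl change in the triazolyl pyridine ether series

The source may report more compounds than this note shows. Statements on the series, on what has been measured and on what is new or still open speak of the compounds shown alone.

Compound 3 `CCN(CC)CCn1cnnc1-c1cc(Oc2ccc(NC(=O)Nc3ccc(Cl)c(C(F)(F)F)c3)cc2F)ccn1` gives 900 nM in a functional assay on HT-29 cells (Homo sapiens) for antiproliferative activity, read by MTT assay, with a stated time of 72 h (on this read-out lower numbers stand for stronger inhibition and higher numbers for weaker inhibition), within the scatter of compound 2 `CN(C)CCn1cnnc1-c1cc(Oc2ccc(NC(=O)Nc3ccc(Cl)c(C(F)(F)F)c3)cc2F)ccn1`, which gives 880 nM; the step of a 1.0-fold higher number from compound 2 to compound 3 (0.01 log units; within the scatter) concerns the amine and is within the scatter. Compound 1 `Cn1ncnc1-c1cc(Oc2ccc(NC(=O)Nc3cccc(C(F)(F)F)c3)cc2F)ccn1` reaches only the limit > 50000 nM in this assay, a limit and not a number, as the limit of > 50000 nM in this assay, at which 1 of the 3 values shown sits, states. Compound 4 `CCN(CC)CCn1cnnc1-c1cc(Oc2ccc(NC(=O)Nc3ccccc3C(F)(F)F)cc2F)ccn1` differs from compound 3 by 2-(trifluoromethyl)phenyl in place of 4-chloro-3-(trifluoromethyl)phenyl on an amide-type nitrogen. Going by the values given here, no measured step touches the urea aryl, so the series offers no direct guide; compound 1, which differs from compound 2 at both the urea aryl and the amine, sits at the limit. Compound 4 is expected at 12000 nM, range 2500 nM to 50000 nM, an expected step of a 13-fold higher number from compound 3 to compound 4 (1.12 log units; beyond the scatter) toward weaker inhibition.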

Compound 4, half-maximal inhibitory concentration: 3410 nM
For compound 4 the middle estimate is 3.5-fold (0.55 log units) above the measured one; low and high end bracket the measured number.
By their numbers in this assay, from the lowest: compounds 2 and 3 (each within the scatter of the next); then compound 4. At a limit, above all of these: compound 1.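

Going by these compounds alone, the urea aryl is the first place where a single change moves the read-out beyond the scatter: in this assay, 2-(trifluoromethyl)phenyl in place of 4-chloro-3-(trifluoromethyl)phenyl gives a 3.8-fold higher number from compound 3 to compound 4 (0.58 log units; beyond the scatter), toward weaker inhibition. This single step swaps the whole aryl, so the loss of chlorine and the shift of the trifluoromethyl group are not separated. Nothing given here accounts for the size of this step.

Open, from the compounds shown here alone, is how a plain phenyl or a phenyl carrying chlorine alone would read on the same nitrogen. Also open, going by these compounds, is whether a morpholine in place of the diethylamino group would keep the reading of compound 3.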